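Trimethoxyphenyl replaces methylphenyl on the amidine-bearing amine

A few compounds are considered here, and "the series" means these few. Any claim that something is new, unique, unknown or untested is made for them only; others in the source may bear on it.

Of the compounds shown here, three sharing one core have been measured in a functional assay on HeLa cells (Homo sapiens) for cytotoxicity, read by MTT assay, with a stated time of 48 h; on this read-out lower numbers stand for stronger inhibition and higher numbers for weaker inhibition. Compound 1 `COc1ccc(N/C(CCNC2=CC(=O)c3ccccc3C2=O)=N\S(=O)(=O)c2ccc(C)cc2)cc1` gives 7590 nM. Compound 2 `Cc1ccc(S(=O)(=O)/N=C(/CCNC2=CC(=O)c3ccccc3C2=O)Nc2ccc(Cl)cc2)cc1` gives 13400 nM. Compound 3 `Cc1ccc(S(=O)(=O)/N=C(/CCNC2=CC(=O)c3ccccc3C2=O)Nc2cccc(C)c2)cc1` gives 9060 nM. Among these three numbers compound 3 stands closest to compound 1 and furthest from compound 2, and both gaps are within the scatter, so the three compounds cannot be told apart on this read-out.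

The next compound, compound 4 `COc1cc(N/C(CCNC2=CC(=O)c3ccccc3C2=O)=N\S(=O)(=O)c2ccc(C)cc2)cc(OC)c1OC`, changes the aromatic ring on the amine nitrogen: 3,4,5-trimethoxyphenyl in place of 3-methylphenyl on an amine nitrogen.

All three measured steps concern exactly this ring and so bear on the change. Swapping a methoxy for a chloro gave a 1.8-fold higher number from compound 1 to compound 2 (0.25 log units; within the scatter); replacing 4-methoxyphenyl with 3-methylphenyl gave a 1.2-fold higher number from compound 1 to compound 3 (0.08 log units; within the scatter); and replacing 4-chlorophenyl with 3-methylphenyl gave a 1.5-fold lower number from compound 2 to compound 3 (0.17 log units; within the scatter). None of these moved the number beyond the scatter, although none of them added three methoxy groups at once, so the new ring is a larger change than any step seen. No step beyond the scatter is expected in this assay in either direction. Compound 4 is therefore estimated at 9000 nM, with a range from 3000 nM to 27000 nM. For compound 4 this estimate means an expected step of a 1.0-fold lower number from compound 3 to compound 4 (0.00 log units; within the scatter).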

Compound 4, half-maximal inhibitory concentration: 3390 nM
Compound 4: middle estimate off by 2.7-fold (0.42 log units), on the high side; measured number inside the range.
By their numbers in this assay, from the lowest: compound 4; then compounds 1, 3 and 2 (each within the scatter of the next).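

On the amine nitrogen whose other neighbour is a carbon with a double bond to nitrogen, the ring swaps among compound 1, compound 2 and compound 3 all stayed within the scatter in this assay, but 3,4,5-trimethoxyphenyl moves the number beyond it against each of them: a 2.7-fold lower number from compound 3 to compound 4 (0.43 log units; beyond the scatter), a 4.0-fold lower number from compound 2 to compound 4 (0.60 log units; beyond the scatter) and a 2.2-fold lower number from compound 1 to compound 4 (0.35 log units; beyond the scatter). All three steps are modest and point the same way, so this position does respond to the ring it carries, and compound 4 has the lowest number of the four, which here stands for the strongest inhibition. The change adds three methoxy groups, but nothing measured here explains why the number falls.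

The compounds shown leave open whether all three methoxy groups are needed, a question that a phenyl ring carrying only two methoxy groups would help to settle. They also leave open whether longer ethoxy chains in place of the methoxy groups, or a ring bearing an amine or a carboxylic acid, would lower the number further or lose the step.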